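The source may report more compounds than this note shows. Statements on the series, on what has been measured and on what is new or still open speak of the compounds shown alone.

Three compounds share one core, with a benzyl group on an aromatic nitrogen and an amide carrying a branched benzylic substituent. In an in vitro ADME assay on microsomes from liver (Homo sapiens) for metabolic stability (on this read-out higher numbers stand for fast clearance and lower numbers for slow clearance), compound 1 `CCC(NC(=O)c1ccc2c(c1)nc(C)n2Cc1ccc(Cl)c(Cl)c1)c1ccccc1` gives 0.5 mL.min-1.g-1, and compound 2 `Cc1nc2cc(C(=O)N[C@H](C)c3ccccc3)ccc2n1Cc1ccc(Cl)c(Cl)c1` gives 0.5 mL.min-1.g-1; the step of no change at the digits printed from compound 1 to compound 2 (within the scatter) sits within the scatter. Compound 3 `CC[C@@H](NC(=O)c1ccc2c(c1)ncn2Cc1ccc(Cl)c(Cl)c1)c1ccccc1` lacks the methyl on the core of compound 1. In this assay compound 3 gives 0.6 mL.min-1.g-1, a number that lies within the scatter of both compound 1 and compound 2, so the three are indistinguishable on these measurements. Compound 4 `CC[C@@H](NC(=O)c1ccc2c(c1)ncn2Cc1ccc(F)cc1F)c1ccccc1` differs from compound 3 by 2,4-difluorophenyl in place of 3,4-dichlorophenyl on a saturated chain carbon bound to an aromatic nitrogen. Within the data shown here, no measured step touches that benzyl group, so nothing here speaks for a move beyond the scatter. Compound 4 is therefore expected to give 0.6 mL.min-1.g-1 in this assay, between 0.3 mL.min-1.g-1 and 1.3 mL.min-1.g-1, a step of no change at the digits printed from compound 3 to compound 4 (within the scatter) that is estimated to stay within the scatter.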

Compound 4, intrinsic clearance in microsomes: 0.5 mL.min-1.g-1
The estimate for compound 4 lay 1.2-fold (0.08 log units) above the measured number; the measured number falls inside the stated range.
By their numbers in this assay, from the lowest: compounds 1, 2, 4 and 3 (each within the scatter of the next).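

Putting 2,4-difluorophenyl in place of 3,4-dichlorophenyl on a saturated chain carbon bound to an aromatic nitrogen gives a 1.2-fold lower number from compound 3 to compound 4 (0.08 log units; within the scatter) in this assay. Among these compounds, this is the first measured step at this place, and on this read-out the two halogenated rings cannot be told apart there. Nothing available offers an explanation for this result. The compounds shown leave open whether an unsubstituted phenyl, or a phenyl carrying an amine or a carboxylic acid, would also stay within the scatter at this place. They also leave open whether 2,4-difluorophenyl would behave alike on the core of compound 1.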